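The source may hold more compounds than are shown below. What is called first, only, known or untested is meant among the compounds shown, and "the series" means these compounds.

Compound 1 `CCCCCN(Cc1ccc(C(=O)NO)cc1)c1ncc(-c2ccc(C)cc2)s1`: 5060 nM
Compound 2 `Cc1ccc(OCCCN(Cc2ccc(C(=O)NO)cc2)c2ncc(-c3ccc(C)cc3)s2)cc1`: 9330 nM
Compound 3 `Cc1ccc(-c2cnc(N(CCCCOc3ccccc3)Cc3ccc(C(=O)NO)cc3)s2)cc1`: 10300 nM

These three compounds share a common core and were tested in a functional assay on PC-3 cells (Homo sapiens) for antiproliferative activity, read by MTT assay, with a stated time of 48 h; a lower number here means a stronger inhibitor of growth, a higher number a weaker inhibitor of growth. On the numbers shown, compound 1 has the lowest value, with compound 2 nearest to it and compound 3 furthest away, the steps being a 1.8-fold higher number from compound 1 to compound 2 (0.27 log units; within the scatter) and a 2.0-fold higher number from compound 1 to compound 3 (0.31 log units; beyond the scatter). The gap between compound 2 and compound 3 is a 1.1-fold higher number from compound 2 to compound 3 (0.04 log units; within the scatter).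

Compound 4 `Cc1ccc(-c2cnc(N(CCCOc3ccccc3)Cc3ccc(C(=O)NO)cc3)s2)cc1` has not yet been measured in this assay. It differs from compound 1 as follows: phenoxy in place of ethyl on a saturated chain carbon, three bonds along the chain from a nitrogen on an aromatic ring. Going by the values given here, two measured steps bear on this change. The step from compound 1 to compound 2 puts a closely related group at the same place and gives a 1.8-fold higher number from compound 1 to compound 2 (0.27 log units; within the scatter); the step from compound 1 to compound 3 puts the same group one bond further out and gives a 2.0-fold higher number from compound 1 to compound 3 (0.31 log units; beyond the scatter). Both point the same way, toward a modest rise in the number. For compound 4 a step of a 1.9-fold higher number from compound 1 to compound 4 (0.27 log units; within the scatter) is therefore expected, giving an estimated value of 9500 nM with a range from 4500 nM to 20000 nM.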

Compound 4, concentration for 50% growth inhibition: 17500 nM
The estimate for compound 4 lay 1.8-fold (0.27 log units) below the measured number; the range from low to high includes it.
By their numbers in this assay, from the lowest: compounds 1, 2, 3 and 4 (each within the scatter of the next, the first and the last beyond it).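

Putting phenoxy in place of ethyl at this place on the chain, in this assay, gives a 3.5-fold higher number from compound 1 to compound 4 (0.54 log units; beyond the scatter), so this change now has a step clearly beyond the scatter, whereas the nearest phenoxy compound, compound 2, stays within the scatter of compound 1. The details of the phenoxy-bearing chain cannot be separated here: shortening it gives a 1.7-fold higher number from compound 3 to compound 4 (0.23 log units; within the scatter), and removing the methyl on the aromatic ring gives a 1.9-fold higher number from compound 2 to compound 4 (0.27 log units; within the scatter), both within the scatter. Nothing measured here explains why the phenoxy chain in compound 4 gives a higher number than the pentyl chain in compound 1.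

The compounds shown leave open whether the ring or the oxygen of phenoxy drives this step. A benzyl group or an amine in place of phenoxy at the same place would help to tell these apart.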